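Predicting Compound 3 from Two Measured Analogues

The compounds below may be only part of what the source reports. "The series", "measured", "known", "first", "only" and "open" are said of these compounds alone.

Measured compounds:
compound 1, `CCOC(=O)Oc1cc(-c2cncnc2-c2cc(OC)c(OC)c(OC)c2)ccc1OC`, gives 1890 nM in a functional assay on SiHa cells (Homo sapiens) for antiproliferative activity, read by CCK-8 assay, with a stated time of 72 h; a higher number here means a weaker inhibitor, a lower number a stronger inhibitor
compound 2, `COc1ccc(-c2cncnc2-c2cc(OC)c(OC)c(OC)c2)cc1F`, gives 3340 nM in this assay

Among these two numbers in this assay, compound 2 has the higher one, yet its only neighbour is compound 1, and the step of a 1.8-fold higher number from compound 1 to compound 2 (0.25 log units; within the scatter) lies within the scatter, so the two cannot be placed in order. Compound 3, `CCSc1ccc(-c2cncnc2-c2cc(OC)c(OC)c(OC)c2)cc1`, has not yet been measured. It differs from compound 2 in one place: 4-(ethylsulfanyl)phenyl in place of 3-fluoro-4-methoxyphenyl on an aromatic carbon. For the measured compounds named here, the single measured step, a 1.8-fold higher number from compound 1 to compound 2 (0.25 log units; within the scatter), exchanges one group on the very ring that is replaced here and left the number within the scatter; no measured step exchanges that whole ring, so the data give no guide to direction. The step of a 1.3-fold lower number from compound 2 to compound 3 (0.13 log units; within the scatter) is therefore expected to remain within the scatter. For compound 3 the estimate in this assay is 2500 nM, with a range from 700 nM to 9000 nM.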

Compound 3, half-maximal inhibitory concentration: 1030 nM
Compound 3: the middle estimate sits 2.4-fold (0.39 log units) above what was measured; low and high end bracket the measured number.
By their numbers in this assay, from the lowest: compounds 3, 1 and 2 (each within the scatter of the next, the first and the last beyond it).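

In this assay, replacing 3-fluoro-4-methoxyphenyl with 4-(ethylsulfanyl)phenyl on this aromatic carbon, ortho to a large group and two atoms from the ring nitrogen, gives a step beyond the scatter (a 3.2-fold lower number from compound 2 to compound 3 (0.51 log units; beyond the scatter)), whereas the earlier exchange of one group on that ring stayed within it (a 1.8-fold higher number from compound 1 to compound 2 (0.25 log units; within the scatter)). The number at this position therefore does respond to the group placed there, even though the leaving and entering groups match in heavy atoms, hydrogen-bond donors, hydrogen-bond acceptors and net charge. Nothing measured here explains the step.

For the compounds shown here, the single exchange alters several features of the ring together, so the part played by the sulfur, the ethyl chain or the lost fluoro group remains unresolved. Also open, as far as these compounds go, is how a longer chain on the sulfur, or an amine in its place, would read in this assay.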